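Trading a methylcyclopropyl group for a straight chain

This account rests on a few compounds, and the source may have more. Where it says the series, first, only, none or still open, it means among the compounds named here.

- Compound 1 `CC1(C[C@@H](O)C(=O)N2N=CC[C@H]2C(=O)NCc2cc(Cl)ccc2-n2cnnn2)CC1` gives 730 nM
- Compound 2 `O=C(NCc1cc(Cl)ccc1-n1cnnn1)[C@@H]1C[C@H]2C[C@H]2N1C(=O)[C@H](O)c1ccccc1` gives 680 nM
- Compound 3 `COC(C)(C)[C@@H](O)C(=O)N1C[C@H]2C[C@H]2[C@H]1C(=O)NCc1cc(Cl)ccc1-n1cnnn1` gives 1000 nM

These three compounds were tested in a functional assay on a cell-free system (plasma, Homo sapiens), with a stated time of 3 min (on this read-out lower numbers stand for stronger inhibition and higher numbers for weaker inhibition), and give closely grouped numbers. Compound 1 has compound 2 as its nearest neighbour and compound 3 as its furthest, and both gaps lie within the usual scatter of repeated measurements. Among the measured compounds shown here, no pair of measured compounds differs in only one place, so the data do not isolate the effect of any single change.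

Compound 4 `CCCC[C@@H](O)C(=O)N1N=CC[C@H]1C(=O)NCc1cc(Cl)ccc1-n1cnnn1` is still to be measured. It differs from compound 1 in one place: propyl in place of 1-methylcyclopropyl on a saturated chain carbon, two bonds along the chain from a carbonyl carbon and an oxygen on a saturated carbon. The propyl replaces the 1-methylcyclopropyl on a saturated chain carbon, two bonds along the chain from a carbonyl carbon and an oxygen on a saturated carbon. Cut one bond further out, the same difference reads (1-methylcyclopropyl)methyl to butyl.

For the measured compounds named here, no measured compound carries this butyl, so the expectation rests on a thin basis. Compound 1 at 730 nM is its only close relative. The expected result is no step beyond the scatter, with only a slight lean towards weaker inhibition. The estimated move, a 1.2-fold higher number from compound 1 to compound 4 (0.07 log units; within the scatter), is expected to stay small. For compound 4 the estimated value is 850 nM, within an expected range of 300 nM to 2400 nM.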

Compound 4, half-maximal inhibitory concentration: 610 nM
For compound 4 the middle estimate is 1.4-fold (0.14 log units) above the measured one, and the stated range covers the measured number.
By their numbers in this assay, from the lowest: compounds 4, 2, 1 and 3 (each within the scatter of the next).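

Among the compounds shown here, this is the first comparison here that changes a single place, and it gives a direct reading for this position on the core of compound 1. Replacing 1-methylcyclopropyl with propyl, on a saturated chain carbon two bonds along the chain from a carbonyl carbon and an oxygen on a saturated carbon, gives a 1.2-fold lower number from compound 1 to compound 4 (0.08 log units; within the scatter). The three-membered ring can therefore be opened out into a straight butyl chain with no measurable step on this read-out, although the data offer no explanation for this result.

The compounds shown leave open whether a longer chain such as hexyl, a shorter one such as ethyl, or a butyl chain ending in an amine or a carboxylic acid would also stay within the scatter at this place. They also leave open whether the same exchange would behave alike on the cores of compound 2 and compound 3, which differ from compound 4 in more than one place and so offer no clean comparison.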